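Moving the Hydroxyl Group on the Pyridinyl Core Series

This account rests on a few compounds, and the source may have more. Where it says the series, first, only, none or still open, it means among the compounds named here.

Measured so far in a functional assay on T47D cells (Homo sapiens) for cytotoxicity, read by CCK-8 assay; on this read-out higher numbers stand for weaker inhibition and lower numbers for stronger inhibition:
Compound 1 `Oc1cccc(-c2cc(-c3ccoc3)cc(-c3cccc(O)c3)n2)c1` gives 2590 nM.
Compound 2 `Oc1ccc(-c2cc(-c3ccoc3)cc(-c3cccc(O)c3)n2)cc1` gives 2610 nM.
Compound 3 `Oc1cccc(-c2cc(-c3cccnc3)cc(-c3cccc(O)c3)n2)c1` gives only a limit, > 50000 nM.

Compound 1 and compound 2 share one core and differ in one place: 4-hydroxyphenyl in place of 3-hydroxyphenyl on an aromatic carbon. The step is a 1.0-fold higher number from compound 1 to compound 2 (0.00 log units; within the scatter), so the two values cannot be told apart in this assay. Compound 1 and compound 3 differ in the group on the opposite side of the core: pyridin-3-yl in place of furan-3-yl on an aromatic carbon. Here the step is an at least 19-fold higher number from compound 1 to compound 3 (1.28 log units; beyond the scatter), and the value of compound 3 is one of those sitting at the limit of > 50000 nM in this assay, at which 1 of the 3 values shown sits, which is a limit of this assay and not a number.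

Compound 4 `Oc1ccc(-c2cc(-c3cccnc3)cc(-c3cccc(O)c3)n2)cc1` has not yet been measured in this assay. It stands to compound 3 as compound 2 stands to compound 1: 4-hydroxyphenyl in place of 3-hydroxyphenyl on an aromatic carbon. The surroundings are not identical, since the group is meta to a pyridin-3-yl group in compound 4 rather than meta to a furan-3-yl group in compound 2, so this is the same kind of change, not the same change.

For compound 4 the step is expected to be a step that the limit leaves unreadable from compound 3 to compound 4, set beside the measured 1.0-fold higher number from compound 1 to compound 2 (0.00 log units; within the scatter), because compound 3 gives > 50000 nM and the earlier change left the value unmoved. Compound 4 is therefore estimated at 60000 nM, with a range from 20000 nM to 200000 nM, and most likely the assay will again report only a limit.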

Compound 4, half-maximal inhibitory concentration: > 50000 nM
Compound 4 gave a limit, no number; the forecaster's own chance of this, stated with the estimate: 75%; the middle value lies beyond the limit too.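

In this assay, pyridin-3-yl in place of furan-3-yl on the core of compound 2 gives an at least 19-fold higher number from compound 2 to compound 4 (1.28 log units; beyond the scatter). The direction of this change therefore holds on both cores shown, but each size is known only as a minimum, so the data do not show that the change costs the same amount on each core: the same change on two cores in this assay, an at least 19-fold higher number (1.28 log units; beyond the scatter) from compound 1 to compound 3 and an at least 19-fold higher number (1.28 log units; beyond the scatter) from compound 2 to compound 4; the limit leaves it open whether they differ

Compound 4 gives > 50000 nM, which is a limit of the assay and not a number, and the step between compound 3 and compound 4 cannot be read, so the pyridin-3-yl pair says nothing about whether 4-hydroxyphenyl and 3-hydroxyphenyl are interchangeable on that core: the limit of > 50000 nM in this assay, at which 2 of the 4 values shown sit.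

Still open, going by these compounds, is whether the values of compound 1 and compound 2 depend on the furan-3-yl group specifically, or whether a thiophen-3-yl or a plain phenyl group at the same place would keep a measurable value in this assay. Also open, on these data alone, is whether the hydroxyl groups themselves are needed, which a methoxy group or an amine in their place on the core of compound 1 would test.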